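Tolyl ester variant of compound 1: cytotoxicity outlook

A few compounds are considered here, and "the series" means these few. Any claim that something is new, unique, unknown or untested is made for them only; others in the source may bear on it.

Compound 1 `O=c1cc(N2CCN(CC3CCC(OS(=O)(=O)c4cccnc4)CC3)CC2)sc2c([N+](=O)[O-])cc(C(F)(F)F)cc12` is the reference of the series. In an ADME assay on Vero cells (Chlorocebus sabaeus) for cytotoxicity, read by MTT assay, with a stated time of 48 h (on this read-out lower numbers stand for stronger inhibition and higher numbers for weaker inhibition), compound 1 gives only a limit, > 64 ug/mL. Compound 2 `CC(=O)NC1CCC(CN2CCN(c3cc(=O)c4cc(C(F)(F)F)cc([N+](=O)[O-])c4s3)CC2)CC1` also returns a limit in this assay, > 64 ug/mL. Compound 3 `O=C(OC1CCC(CN2CCN(c3cc(=O)c4cc(C(F)(F)F)cc([N+](=O)[O-])c4s3)CC2)CC1)c1ccc(F)cc1` returns a limit too, > 64 ug/mL. All three values sit at the limit of > 64 ug/mL in this assay, at which 3 of the 3 values shown sit, so neither a step that the two limits leave unreadable from compound 1 to compound 2 nor a step that the two limits leave unreadable from compound 1 to compound 3 can be sized. Compound 4 `Cc1ccc(C(=O)OC2CCC(CN3CCN(c4cc(=O)c5cc(C(F)(F)F)cc([N+](=O)[O-])c5s4)CC3)CC2)cc1` differs from compound 1 by (4-methylphenyl)carbonyl in place of (pyridin-3-yl)sulfonyl on an oxygen on a saturated carbon. The closest measured comparison, a step that the two limits leave unreadable from compound 1 to compound 3, changes the same oxygen on a saturated carbon with both ends at the limit. Expected, therefore, is no readable step beyond the scatter, a step that the limit leaves unreadable from compound 1 to compound 4, with compound 4 most likely returning a limit again. The estimate for compound 4 is 80 ug/mL, within 40 ug/mL to 200 ug/mL.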

Compound 4, half-maximal inhibitory concentration: > 64 ug/mL
Compound 4 was reported as a limit (the forecaster's own chance of this, stated with the estimate: 85%); the middle value lies beyond the limit too.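

Compound 4, like compound 1, compound 2 and compound 3, is reported only as a limit in this assay, so no step among them can be read: the limit of > 64 ug/mL in this assay, at which 4 of the 4 values shown sit.

Still open, on these data alone, is whether any of these changes alters cytotoxicity at all.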